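Aryl variation on the pyrazole core: compound 4 estimated

This account rests on a few compounds, and the source may have more. Where it says the series, first, only, none or still open, it means among the compounds named here.

Three compounds with the shared core of compound 1 `COc1ccc(-c2c(C)nn(-c3nc(-c4ccc(Cl)c(Cl)c4)c(SC(C)C)s3)c2C(=O)O)cc1` have been measured in a functional assay on BJAB cells (Homo sapiens) for antiproliferative activity, with a stated time of 4 days; on this read-out higher numbers stand for an effect only at larger amounts of compound and lower numbers for an effect already at smaller amounts. Compound 1 gives 2100 nM. Compound 2 `COc1cncc(-c2c(C)nn(-c3nc(-c4ccc(Cl)c(Cl)c4)c(SC(C)C)s3)c2C(=O)O)c1` gives 21000 nM, and compound 3 `Cc1cc(C#N)cc(-c2c(C)nn(-c3nc(-c4ccc(Cl)c(Cl)c4)c(SC(C)C)s3)c2C(=O)O)c1` gives 4800 nM. Among these three, compound 3 stands second highest: a 2.3-fold higher number from compound 1 to compound 3 (0.36 log units; beyond the scatter), and a 4.4-fold lower number from compound 2 to compound 3 (0.64 log units; beyond the scatter). The remaining step, a 10-fold higher number from compound 1 to compound 2 (1.00 log units; beyond the scatter), is the largest in the set.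

Compound 4 `COc1ccccc1-c1c(C)nn(-c2nc(-c3ccc(Cl)c(Cl)c3)c(SC(C)C)s2)c1C(=O)O` is not yet measured. It differs from compound 3 by 2-methoxyphenyl in place of 3-cyano-5-methylphenyl on an aromatic carbon. Among the measured compounds shown here, the step bearing most directly on this change is the one in which 4-methoxyphenyl was replaced by 3-cyano-5-methylphenyl, a 2.3-fold higher number from compound 1 to compound 3 (0.36 log units; beyond the scatter), which is modest; the reverse direction, back to a methoxyphenyl, would then be expected to give a somewhat lower number, though 2-methoxyphenyl and 4-methoxyphenyl are not the same group and no measured step separates them. A small step downward in this assay, near or within the scatter, is therefore expected: a 1.5-fold lower number from compound 3 to compound 4 (0.18 log units; within the scatter). The estimate for compound 4 is 3200 nM, with a range of 1100 nM to 10000 nM.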

Compound 4, half-maximal effective concentration: 14700 nM
Compound 4: the middle estimate sits 4.6-fold (0.66 log units) below what was measured; the measured number lies above the stated range.
By their numbers in this assay, from the lowest: compound 1; then compound 3; then compounds 4 and 2 (each within the scatter of the next).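

Working from this assay, 2-methoxyphenyl in place of 4-methoxyphenyl is the first pair in the series that differs only in the placement of the methoxy group, and that placement alone matters here (a 7.0-fold higher number from compound 1 to compound 4 (0.85 log units; beyond the scatter)). A methoxyphenyl at this position therefore does not itself secure the lowest number in the set, since 2-methoxyphenyl also compares unfavourably with 3-cyano-5-methylphenyl (a 3.1-fold higher number from compound 3 to compound 4 (0.49 log units; beyond the scatter)). Against 5-methoxypyridin-3-yl the change stays within the scatter (a 1.4-fold lower number from compound 2 to compound 4 (0.15 log units; within the scatter)), so these two quite different groups share the high end of the series.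

No supporting data bear on the reason for these differences. Open, going by these compounds, is where 3-methoxyphenyl would fall relative to the 2-methoxyphenyl and 4-methoxyphenyl groups, and whether a hydroxy group or an amine at the 4-position of the phenyl would match the methoxy there.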